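Replacing 4-hydroxy-2-methylphenyl with 4-ethylphenyl on the shared core

The compounds below may be only part of what the source reports. "The series", "measured", "known", "first", "only" and "open" are said of these compounds alone.

In a functional assay on K562 cells (Homo sapiens) for inhibition, read by sulforhodamine B assay, with a stated time of 48 h (a lower number here means a stronger inhibitor of growth, a higher number a weaker inhibitor of growth), compound 1 `Cc1ccc(C2=NN(c3ccc(S(C)(=O)=O)cc3)C(=O)CC2)cc1` gives 370 nM and compound 2 `Cc1cc(O)ccc1C1=NN(c2ccc(S(C)(=O)=O)cc2)C(=O)CC1` gives 3740 nM, so compound 2 holds the higher of the two numbers and is the weaker inhibitor of growth. The next structure, compound 3 `CCc1ccc(C2=NN(c3ccc(S(C)(=O)=O)cc3)C(=O)CC2)cc1`, has 4-ethylphenyl in place of 4-hydroxy-2-methylphenyl on a carbon with a double bond to nitrogen. Within the data shown here, one measured step bears on this change: a 10-fold higher number from compound 1 to compound 2 (1.00 log units; beyond the scatter), which came with 4-hydroxy-2-methylphenyl replacing 4-methylphenyl and lies beyond the scatter. Compound 3, like compound 1, carries no hydroxy group, and its 4-ethylphenyl resembles the 4-methylphenyl of compound 1. A step of similar size towards a lower number is therefore expected in this assay, estimated as a 9.4-fold lower number from compound 2 to compound 3 (0.97 log units; beyond the scatter). For compound 3 the estimated value is 400 nM, with an expected range of 130 nM to 1200 nM.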

Compound 3, concentration for 50% growth inhibition: 420 nM
Compound 3: middle estimate off by 1.1-fold (0.02 log units), on the low side; measured number inside the range.
By their numbers in this assay, from the lowest: compounds 1 and 3 (each within the scatter of the next); then compound 2.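

In this assay, 4-ethylphenyl in place of 4-hydroxy-2-methylphenyl gives an 8.9-fold lower number from compound 2 to compound 3 (0.95 log units; beyond the scatter), a return to about the level of compound 1. Lengthening the methyl of 4-methylphenyl to the ethyl of 4-ethylphenyl gives a 1.1-fold higher number from compound 1 to compound 3 (0.06 log units; within the scatter), so this position accepts either small chain with no difference that can be read. Compound 2 therefore remains the only one of the three with a number set apart, and it is also the only one with a hydroxy group, though nothing shown gives the cause of this.

The compounds shown do not tell which part of 4-hydroxy-2-methylphenyl goes with the weaker growth inhibition, the hydroxy group or the methyl. They also leave open how a longer chain such as propyl, or a methoxy group, would fare at this position.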